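The source may hold more compounds than are shown below. What is called first, only, known or untested is meant among the compounds shown, and "the series" means these compounds.

Measured compounds: compound 1 `CC[C@@H](c1nc2ccc(C(=O)O)cc2n1C)N1C(=O)CN(c2ccc(Oc3ccccc3)cc2)C1=O` gives 210000 nM in an assay on isolated protein for inhibition of Bile acid receptor (Homo sapiens), read by TR-FRET and LanthaScreen; a lower number here means a stronger inhibitor, a higher number a weaker inhibitor; compound 2 `CC(C)C[C@@H](c1nc2ccc(C(=O)O)cc2n1C)N1CCN(c2ccc(Oc3ccccc3)cc2)C1=O` gives 28500 nM in this assay.

Within the data shown here, compound 1 stands at the highest of the two numbers, and compound 2, the only neighbour, lies lower by a margin beyond the scatter. Compound 3 `Cn1c([C@@H](N2C(=O)CN(c3ccc(Oc4ccccc4)cc3)C2=O)C(C)(C)C)nc2ccc(C(=O)O)cc21` differs from compound 1 by tert-butyl in place of ethyl on a saturated chain carbon bound to an amide-type nitrogen in a ring and an aromatic carbon. Among the measured compounds shown here, no measured pair isolates this change. Compound 2 carries a larger chain on a different core and gives 28500 nM in this assay, so a larger group is expected to lower the number somewhat: the expected step is a 2.6-fold lower number from compound 1 to compound 3 (0.42 log units; beyond the scatter), modest but beyond the scatter. Compound 3 is estimated at 80000 nM, within 20000 nM to 300000 nM.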

Compound 3, half-maximal inhibitory concentration: 77100 nM
Compound 3: middle estimate off by 1.0-fold (0.02 log units), on the high side; measured number inside the range.
By their numbers in this assay, from the lowest: compound 2; then compound 3; then compound 1.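

Tert-butyl in place of ethyl on a saturated chain carbon bound to an amide-type nitrogen in a ring and an aromatic carbon gives a 2.7-fold lower number from compound 1 to compound 3 (0.44 log units; beyond the scatter) in this assay, with the rest of the compound unchanged. Among these compounds, this is the first reading of this position alone, and it shows that the larger chain group lowers the number rather than raising it. Nothing at hand accounts for this step.

As far as these compounds go, whether isopropyl, a longer chain or an amine at this carbon would continue the trend stays open. So does whether the same change would give a similar step on the core of compound 2.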